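This account rests on a few compounds, and the source may have more. Where it says the series, first, only, none or still open, it means among the compounds named here.

In a functional assay on MCF7 cells (Homo sapiens) for cytotoxicity, read by MTT assay, with a stated time of 6 days (on this read-out higher numbers stand for an effect only at larger amounts of compound and lower numbers for an effect already at smaller amounts), compound 1 `COC(=O)c1c(-c2ccc(OCc3ccccc3)cc2)oc2ccccc2c1=O` gives > 25 ug/mL, which is a limit of the assay. Compound 2 `COc1cc(-c2cc(=O)c3ccc(O)cc3o2)cc(OC)c1OC` also gives only a limit, > 25 ug/mL, so no number fixes where it stands. Compound 3 `COc1cc(-c2cc(=O)c3cc(O)ccc3o2)cc(OC)c1O[Si](C)(C)C(C)(C)C` gives a measured 2.01 ug/mL. Compound 4 `COc1cc(-c2cc(=O)c3ccc(O)cc3o2)cc(OC)c1O[Si](C)(C)C(C)(C)C` departs from compound 2 in one place: a group of 7 heavy atoms (6 carbon, 1 silicon; no ring) in place of one carbon atom, on an oxygen on an aromatic ring. The methyl leaves on an oxygen on an aromatic ring, and the new group takes its place there. The expectation rests on compound 3, which carries the same entering group and gives 2.01 ug/mL. The step expected in this assay is an at least 8.3-fold lower number from compound 2 to compound 4 (0.92 log units; beyond the scatter), toward smaller amounts and beyond the scatter. For compound 4 the estimated value is 3 ug/mL, with an expected range of 1 ug/mL to 12 ug/mL.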

Compound 4, concentration for half-maximal effect: 4.47 ug/mL
The estimate for compound 4 lay 1.5-fold (0.17 log units) below the measured number; the range from low to high includes it.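

In this assay, replacing the methyl on an oxygen on an aromatic ring with the group of 7 heavy atoms containing silicon gives an at least 5.5-fold lower number from compound 2 to compound 4 (0.74 log units; beyond the scatter), the first single change among these compounds that can be read. Compound 2 gives only a limit of the assay, so this step is a minimum and its full size remains unfixed: the limit of > 25 ug/mL in this assay, at which 2 of the 4 values shown sit.

The compounds shown leave open whether a trimethylsilyl group or an all-carbon butyl chain on this oxygen would also lower the number. They also leave open how a free hydroxyl there would compare.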